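Urotensin-2 receptor agonist series: trifluoromethyl for hydrogen

A few compounds are considered here, and "the series" means these few. Any claim that something is new, unique, unknown or untested is made for them only; others in the source may bear on it.

Measured so far:
compound 1 `COc1ccc(/C=C/C(=O)NC(CCN(C)C)c2ccc(C)cc2)cc1` — 2000 nM
compound 2 `Cc1ccc(C(CCN(C)C)NC(=O)/C=C/c2ccccc2)cc1` — 1550 nM

In a functional assay on NIH3T3 cells for agonist activity at Urotensin-2 receptor (Homo sapiens), with a stated time of 5 days (a lower number here means that less compound is needed, a higher number that more compound is needed for the effect), compound 2 gives 1550 nM. For the measured compounds named here, compound 1 gives 2000 nM in this assay, and the two lie within the scatter of each other: the one measured step, a 1.3-fold lower number from compound 1 to compound 2 (0.11 log units; within the scatter), does not separate them.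

Compound 3 `Cc1ccc(C(CCN(C)C)NC(=O)/C=C/c2ccc(C(F)(F)F)cc2)cc1` is not yet measured. Its difference from compound 2 is trifluoromethyl in place of hydrogen on an aromatic carbon.

Going by the values given here, no measured step exchanges hydrogen for trifluoromethyl. Among the compounds with values here, the only step that bears on the same aromatic carbon is a 1.3-fold lower number from compound 1 to compound 2 (0.11 log units; within the scatter), where replacing methoxy by hydrogen left the number within the scatter. Within the data shown here, with that as the sole guide, the change to compound 3 is expected to stay within the scatter, with no direction favoured; the expected step is a 1.0-fold lower number from compound 2 to compound 3 (0.01 log units; within the scatter).

Compound 3 is therefore estimated at 1500 nM in this assay, with a range from 500 nM to 4500 nM.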

Compound 3, half-maximal effective concentration: 437 nM
Estimate against measurement, compound 3: 3.4-fold (0.54 log units) above; the measured number lies below the stated range.
By their numbers in this assay, from the lowest: compound 3; then compounds 2 and 1 (each within the scatter of the next).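

In this assay the series now holds a step beyond the scatter at this aromatic carbon: a 3.5-fold lower number from compound 2 to compound 3 (0.55 log units; beyond the scatter) with trifluoromethyl entering, so the position para to a large group does respond to substitution, which the pair of methoxy and hydrogen did not show. Trifluoromethyl also separates from methoxy, with a 4.6-fold lower number from compound 1 to compound 3 (0.66 log units; beyond the scatter) at the same carbon, so these two groups are not interchangeable here, although hydrogen and methoxy could not be told apart. Nothing given here bears on why the number falls with trifluoromethyl.

On these data alone, whether the lower number is particular to trifluoromethyl or also appears with a chlorine atom, a nitrile or a carboxylic acid on that carbon stays open. Also open, as far as these compounds go, is whether trifluoromethyl gives a similar step on another carbon of the same ring.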